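The source may report more compounds than this note shows. Statements on the series, on what has been measured and on what is new or still open speak of the compounds shown alone.

Working notes on the series. In a functional assay on THP-1 cells (Homo sapiens) for inhibition (on this read-out higher numbers stand for weaker inhibition of growth and lower numbers for stronger inhibition of growth), compound 1 `Cc1noc(C)c1-c1ccc2c(c1)c(Cc1ccccc1)cn2CCCCCCC(=O)NO` gives 15500 nM, compound 2 `Cc1noc(C)c1-c1ccc2c(c1)c(CCc1ccccc1)cn2CCCCCCC(=O)NO` gives 15500 nM and compound 3 `Cc1cccc(Cc2cn(CCCCCCC(=O)NO)c3ccc(-c4c(C)noc4C)cc23)c1` gives 15500 nM, so compound 3 stands level with the other two at the digits available.

The next structure is compound 4 `Cc1ccc(Cc2cn(CCCCCCC(=O)NO)c3ccc(-c4c(C)noc4C)cc23)cc1`. The change is 4-methylphenyl in place of 3-methylphenyl on a saturated chain carbon bound to an aromatic carbon, with 4-methylphenyl in place of 3-methylphenyl on a saturated chain carbon bound to an aromatic carbon; cut one bond further out, it reads 3-methylbenzyl to 4-methylbenzyl.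

Going by the values given here, the closest precedent is the addition of methyl in place of hydrogen on an aromatic carbon, which gave no change at the digits printed from compound 1 to compound 3 (within the scatter). The other two measured steps are no change at the digits printed from compound 1 to compound 2 (within the scatter) and no change at the digits printed from compound 2 to compound 3 (within the scatter). Among the compounds with values here, none of the three exceeds the scatter, and no measured pair compares the two methyl placements directly.

No shift beyond the scatter is therefore expected in this assay, and no direction is favoured. The expected step is no change at the digits printed from compound 3 to compound 4 (within the scatter). The estimated value for compound 4 is 15500 nM, with an expected range of 8000 nM to 25000 nM.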

Compound 4, concentration for 50% growth inhibition: 15500 nM
Estimate against measurement, compound 4: no gap at the digits printed; the measured number falls inside the stated range.
By their numbers in this assay, from the lowest: compounds 1, 2, 3 and 4 (each within the scatter of the next).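

In this assay, going by these compounds alone, the move from 3-methylbenzyl to 4-methylbenzyl gives no change at the digits printed from compound 3 to compound 4 (within the scatter), which provides the first direct comparison of the two methyl placements on this saturated chain carbon. Against the two groups without a methyl, the result is the same, with no change at the digits printed from compound 1 to compound 4 (within the scatter) and no change at the digits printed from compound 2 to compound 4 (within the scatter), so neither placement separates from them on this read-out. Nothing on hand offers an explanation for this flat result.

All four compounds share one printed value, so these compounds give no step beyond the scatter at this position and no indication of which change would alter growth inhibition. From the compounds shown here alone, it remains open whether an amine, a carboxylic acid or a methoxy group on the same aromatic ring, or 2-methylbenzyl, would behave differently.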